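Compound 3 and the limit shared by its neighbours

A few compounds are considered here, and "the series" means these few. Any claim that something is new, unique, unknown or untested is made for them only; others in the source may bear on it.

Compound 1 `Cc1cc(NC(=O)Nc2ccccc2N)c2ccccc2n1` gives > 25000 nM in an ADME assay on HEK293 cells (Homo sapiens) for cytotoxicity, with a stated time of 72 h (on this read-out higher numbers stand for an effect only at larger amounts of compound and lower numbers for an effect already at smaller amounts), and this is a limit, not a number.

Compound 2 `Cc1cc(NC(=O)Nc2ncccc2C)c2ccccc2n1` likewise gives only a limit, > 25000 nM in this assay and so has no exact position on the scale.

The evidence so far amounts to the limit of > 25000 nM in this assay, at which 2 of the 2 values shown sit, and nothing more. Within the data shown here, the one measured step runs as a step that the two limits leave unreadable from compound 1 to compound 2 and offers no size to carry forward.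

Compound 3 `Cc1cc(NC(=O)Nc2ccc(N)cc2)c2ccccc2n1` has yet to be measured. It is reached from compound 2 by one change 4-aminophenyl in place of 3-methylpyridin-2-yl on an amide-type nitrogen in which 4-aminophenyl takes the place of 3-methylpyridin-2-yl on an amide-type nitrogen.

Compound 1, with 2-aminophenyl on that nitrogen, sits at the limit > 25000 nM and so no marked effect of an aminophenyl group is expected in this assay here.

The expected outcome is a number no higher from compound 2 to compound 3 (the limit leaves the size open) and no step beyond the scatter is anticipated in either direction.

For compound 3 the estimate is 25000 nM with an expected range from 10000 nM to 50000 nM and a further limit is the likeliest report.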

Compound 3, half-maximal effective concentration: > 25000 nM
Compound 3 gave a limit, no number (the forecaster's own chance of this, stated with the estimate: 70%); the middle value sits exactly at the limit.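

Compound 3 joins compound 1 and compound 2 in giving only a limit, not a number, in this assay, so no step among the three can be read: the limit of > 25000 nM in this assay, at which 3 of the 3 values shown sit.

The compounds shown leave open whether 2-aminophenyl, 3-methylpyridin-2-yl and 4-aminophenyl on the amide-type nitrogen differ at all in this assay, and at what concentration any of the three compounds would show an effect.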